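The compounds below may be only part of what the source reports. "The series", "measured", "known", "first", "only" and "open" are said of these compounds alone.

The compounds share the core of compound 1 `CCCCCn1c(N)nc2c(OC)cccc21`, which in an assay on HEK293 cells for agonist activity at Toll-like receptor 8 (Homo sapiens), read by reporter gene assay (on this read-out lower numbers stand for an effect already at smaller amounts and higher numbers for an effect only at larger amounts of compound), gives 3740 nM. Compound 2 `CCCCCn1c(N)nc2c(C(F)(F)F)cccc21` was reported in this assay as "not active" (no number reported). Compound 3 `CCCCCn1c(N)nc2c(OCc3ccccc3)cccc21` likewise came out in this assay as "not active" (no number reported), so no single number places it on the scale, and it stands with compound 2 among the entries without a number. Compound 4 `CCCCCn1c(N)nc2c(O)cccc21` differs from compound 3 by hydrogen in place of benzyl on an oxygen on an aromatic ring. Among the measured compounds shown here, no measured pair shows this change, so the size and direction of the step in this assay are open; the only number in the set is that of compound 1, which gives 3740 nM, while compound 3 gave none. Compound 4 is expected to give roughly 6000 nM, somewhere between 1500 nM and 25000 nM, with a real chance of again no number.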

Compound 4, half-maximal effective concentration: 5010 nM
For compound 4 the middle estimate is 1.2-fold (0.08 log units) above the measured one; the range from low to high includes it.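

In this assay, replacing the methyl on the oxygen with hydrogen gives a 1.3-fold higher number from compound 1 to compound 4 (0.13 log units; within the scatter) and so leaves the number within the scatter. Compound 4 gives a number where compound 3, with benzyl on that oxygen, gives none, so the step between them cannot be read. Nothing measured here accounts for this result.

As far as these compounds go, what an ethyl or a longer chain on this oxygen would give remains open. So does the effect of an amine in place of the oxygen.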